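Replacing methylamino with morpholin-4-yl on a carbonyl carbon

The compounds below may be only part of what the source reports. "The series", "measured", "known", "first", "only" and "open" are said of these compounds alone.

In a functional assay on MDA-MB-231 cells (Homo sapiens) for inhibition, read by sulforhodamine B assay, with a stated time of 72 h (on this read-out higher numbers stand for weaker inhibition of growth and lower numbers for stronger inhibition of growth), compound 1 (`CNC(=O)/C=C/c1ccncc1-c1ccc2ccccc2c1`) gives 8680 nM as its reading. Compound 3 (`CCOC(=O)/C=C/c1ccncc1-c1ccc2cc[nH]c2c1`) gives 7980 nM as its reading, and these two values lie within the usual scatter of each other. For compound 2 (`CCOC(=O)/C=C/c1ccncc1-c1ccc2c(cnn2C)c1`) the reading is > 10000 nM and this is a limit of the assay, not a number. Compound 1 therefore has a single numerical neighbour, compound 3, and no measured value stands clearly apart from it.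

Compound 4 (`O=C(/C=C/c1ccncc1-c1ccc2ccccc2c1)N1CCOCC1`) keeps the core of compound 1 and still awaits measurement in this assay as the next step. It carries morpholin-4-yl in place of methylamino on a carbonyl carbon, so methylcarbamoyl becomes (morpholin-4-yl)carbonyl. For the measured compounds named here, no two measured compounds differ in one place only, so the data give no measured size for a change of this kind. Starting from compound 1 at 8680 nM in this read-out, no step beyond the scatter is expected in either direction. The expected step is a 1.1-fold higher number from compound 1 to compound 4 (0.04 log units; within the scatter) on this estimate. For compound 4 the estimated value is 9500 nM with an expected range from 4000 nM to 22000 nM in this read-out.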

Compound 4, concentration for 50% growth inhibition: 8980 nM
Beside the measured number, compound 4's estimate is 1.1-fold (0.02 log units) above it; measured number inside the range.
By their numbers in this assay, from the lowest: compounds 3, 1 and 4 (each within the scatter of the next). At a limit, above all of these: compound 2.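

For the compounds shown here, the exchange of methylamino for morpholin-4-yl on a carbonyl carbon gives the first step in this set that can be read between compounds differing in one place: in this assay, it is a 1.0-fold higher number from compound 1 to compound 4 (0.01 log units; within the scatter). At this place, the read-out therefore shows no change that can be told from the scatter when the methylamino group and its hydrogen-bond donor give way to a group with a six-membered non-aromatic ring and no such donor. This flat step is read with caution, because the readings of this series lie close to the top of what the assay reports, and compound 2 is held at a limit, not a number: the limit of > 10000 nM in this assay, at which 1 of the 4 values shown sits.

The compounds shown leave open whether any group on this carbonyl carbon can move the reading beyond the scatter, as a piperazine, a dimethylamino group or a free carboxylic acid in place of methylamino might. They also leave open whether the same exchange reads alike on another core, such as that of compound 3.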